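The source may hold more compounds than are shown below. What is called first, only, known or untested is meant among the compounds shown, and "the series" means these compounds.

Compound 1 `O=C(c1c(O)ccc2cc(-c3cccc(O)c3)ccc12)N1CCCCC1` gives 73% in an in vitro assay on Sf9 cells for inhibition of 17-beta-hydroxysteroid dehydrogenase type 1 (Homo sapiens), tested at 1 uM; on this read-out lower numbers stand for a weaker effect and higher numbers for a stronger effect at the one concentration tested. Compound 2 `CNC(=O)c1c(O)ccc2cc(-c3cccc(O)c3)ccc12` gives 76% in this assay. Compound 3 `O=C(Nc1ccccc1)c1c(O)ccc2cc(-c3cccc(O)c3)ccc12` gives 80% in this assay.

Compound 3 gives the highest of the three numbers, but the gaps that separate it from the others, a number 4 percentage points higher from compound 2 to compound 3 (within the scatter) and a number 7 percentage points higher from compound 1 to compound 3 (within the scatter), both lie within the scatter, so the three measured compounds cannot be told apart on these numbers. The three differ only in the amide-type part on the carbonyl carbon of the shared core, and none of those changes, a number 3 percentage points higher from compound 1 to compound 2 (within the scatter) included, moved the read-out beyond the scatter.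

Compound 4 `O=C(Nc1cccc(O)c1)c1c(O)ccc2cc(-c3cccc(O)c3)ccc12` is not yet measured. It differs from compound 3 by hydroxy in place of hydrogen on an aromatic carbon. Within the data shown here, no measured pair tests a hydroxy on that ring, so the only step that bears on it is the one from methyl to phenyl on the amide-type nitrogen, a number 4 percentage points higher from compound 2 to compound 3 (within the scatter), a small one, and the other two steps around the amide group were equally small. Changes at this end of the molecule have so far left the read-out where it was, so the step of no change at the digits printed from compound 3 to compound 4 (within the scatter) is expected to stay within the scatter, with no direction beyond it. For compound 4 an estimate of 80% in this assay is made, with a range from 68% to 90%.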

Compound 4, a percentage reported as inhibition, at one concentration (the size of the read-out at that concentration, not a potency): 70%
The estimate for compound 4 lay 10 percentage points above the measured number; low and high end bracket the measured number.
By their numbers in this assay, from the lowest: compounds 4, 1, 2 and 3 (each within the scatter of the next).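

Hydroxy in place of hydrogen, on an aromatic carbon meta to a large group, is the first change here made on the anilino phenyl ring itself rather than on the group attached to the carbonyl, and in this assay it gives a number 10 percentage points lower from compound 3 to compound 4 (within the scatter). Set against the other two amides, 3-hydroxyphenyl in place of methyl on the amide-type nitrogen gives a number 6 percentage points lower from compound 2 to compound 4 (within the scatter) and (3-hydroxyphenyl)amino in place of piperidin-1-yl on the carbonyl carbon gives a number 3 percentage points lower from compound 1 to compound 4 (within the scatter), so neither comparison separates compound 4 from its neighbours. The insensitivity seen so far at the amide group thus extends to this ring position for this one change, although no data in hand offer an explanation for the result.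

Going by these compounds, whether a methoxy group, an amine or a carboxylic acid at the same ring position would also leave the read-out within the scatter stays open. Also open, on these data alone, is whether these four compounds would differ in the size of their effect at other concentrations, since only a single concentration was tested.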